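The source may report more compounds than this note shows. Statements on the series, on what has been measured and on what is new or still open speak of the compounds shown alone.

Compound 1 `CCS(=O)(=O)Nc1cccc2c1CCCC2c1c[nH]cn1` gives 6.77 in a functional assay on Urethra for agonist activity at Alpha-1A adrenergic receptor (Oryctolagus cuniculus); a higher number here means a more potent compound, by a factor of ten per unit of this negative logarithm, a lower number a less potent compound.
Compound 2 `CC(=O)Nc1cccc2c1CCCC2c1c[nH]cn1` gives 5.89 in this assay.

Going by the values given here, of these two numbers, compound 2 stands at the lower one; its only neighbour is compound 1, and the step of a number 0.88 log units lower from compound 1 to compound 2 (beyond the scatter) lies beyond the scatter of repeated measurements. The unmeasured compound 3 `CC(C)S(=O)(=O)Nc1cccc2c1CCCC2c1c[nH]cn1` differs from compound 2 in one place: isopropylsulfonyl in place of acetyl on a nitrogen on an aromatic ring. Among the compounds with values here, the single measured step that bears on this change is the one from compound 1 to compound 2, where acetyl in place of ethylsulfonyl on the nitrogen on the aromatic ring cost a number 0.88 log units lower from compound 1 to compound 2 (beyond the scatter). Compound 3 reverses that exchange, bringing back a sulfonyl group, though with an isopropyl rather than an ethyl chain attached to the sulfur. Within the data shown here, no measured pair shows what the extra carbon on that chain does, so the expectation rests on the return of the sulfonyl alone. Compound 3 is therefore expected to gain roughly what compound 2 lost, a step of a number 0.81 log units higher from compound 2 to compound 3 (beyond the scatter) in this assay. For compound 3 the estimated value is 6.7, expected to fall between 6.2 and 7.2.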

Compound 3, negative logarithm of the half-maximal effective concentration: 5.17
The estimate for compound 3 lay 1.53 log units above the measured number; measured number outside the range, below it.
By their numbers in this assay, from the lowest: compound 3; then compound 2; then compound 1.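

On the nitrogen on the aromatic ring, a sulfonyl group does not by itself secure the higher number in this assay: isopropylsulfonyl in place of acetyl gives a number 0.72 log units lower from compound 2 to compound 3 (beyond the scatter). What is attached to the sulfur therefore matters a great deal, as a single methyl in place of hydrogen on the saturated chain carbon bound to the sulfonyl sulfur gives a number 1.60 log units lower from compound 1 to compound 3 (beyond the scatter), enough to turn a sulfonyl compound that stands above the acetyl compound into one that stands below it. Nothing available here explains why this one added methyl has so large an effect.

Going by these compounds, with only ethyl and isopropyl on the sulfur, it remains open whether a smaller methylsulfonyl group, a straight propylsulfonyl chain or a ring such as cyclopropylsulfonyl would keep the number near that of compound 1 or lower it as branching did in compound 3. On these data alone, it is equally open whether branching lowers the number on the carbonyl side too, which a comparison of propionyl with isobutyryl on the same nitrogen could show.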